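A few compounds are considered here, and "the series" means these few. Any claim that something is new, unique, unknown or untested is made for them only; others in the source may bear on it.

Measured in a functional assay on A549 cells (Homo sapiens) for antiproliferative activity, read by MTT assay, with a stated time of 48 h; a lower number here means a stronger inhibitor, a higher number a weaker inhibitor:
compound 1 `COc1ccc(/C=C/c2cc(OC)cc(OC)c2/C=C/C(=O)c2ccc(Cl)c(Cl)c2)cc1`: 5.9 ug/mL
compound 2 `CCCC(C)Oc1ccc(C(=O)/C=C/c2c(/C=C/c3ccc(OC)cc3)cc(OC)cc2OC)cc1`: 9.4 ug/mL
compound 3 `COc1ccc(/C=C/c2cc(OC)cc(OC)c2/C=C/C(=O)c2ccccc2)cc1`: 3.9 ug/mL

Compound 3 gives 3.9 ug/mL. It cannot be separated from compound 1 and stands modestly clear of compound 2 in this assay. Compound 4 `COc1ccc(/C=C/c2cc(OC)cc(OC)c2/C=C/C(=O)c2ccc(C)c(C)c2)cc1` differs from compound 3 as follows: 3,4-dimethylphenyl in place of phenyl on a carbonyl carbon.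

Within the data shown here, two measured steps bear on this change, since both replace a substituted phenyl on the same carbonyl carbon. The first is a 1.5-fold lower number from compound 1 to compound 3 (0.18 log units; within the scatter), and compound 1 carries 3,4-dichlorophenyl where compound 4 carries 3,4-dimethylphenyl. The second, with the larger group of compound 2, is a 2.4-fold lower number from compound 2 to compound 3 (0.38 log units; beyond the scatter). Neither shows substitution giving a lower number than phenyl, so a small rise is expected, with no step beyond the scatter. The expected step is a 1.4-fold higher number from compound 3 to compound 4 (0.15 log units; within the scatter). Compound 4 is estimated at 5.5 ug/mL, with an expected range of 2.8 ug/mL to 10.5 ug/mL.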

Compound 4, half-maximal inhibitory concentration: 0.1 ug/mL
Compound 4: middle estimate off by 55-fold (1.74 log units), on the high side, and the stated range ends above it.
By their numbers in this assay, from the lowest: compound 4; then compounds 3, 1 and 2 (each within the scatter of the next, the first and the last beyond it).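

In this assay, among these compounds, the group on the carbonyl carbon can move the number far more than the earlier compounds showed: 3,4-dimethylphenyl in place of phenyl gives a 39-fold lower number from compound 3 to compound 4 (1.59 log units; beyond the scatter). The identity of the groups on that ring counts, since 3,4-dimethylphenyl in place of 3,4-dichlorophenyl gives a 59-fold lower number from compound 1 to compound 4 (1.77 log units; beyond the scatter), and in place of 4-(1-methylbutoxy)phenyl it gives a 94-fold lower number from compound 2 to compound 4 (1.97 log units; beyond the scatter). Nothing measured here accounts for these steps. The compounds shown leave open whether both methyl groups are needed, and how 4-methylphenyl or 3,4-diethylphenyl would read on the same carbonyl carbon.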